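This account rests on a few compounds, and the source may have more. Where it says the series, first, only, none or still open, it means among the compounds named here.

Measured compounds:
compound 1 `O=C(Nc1ncc(Cc2ccc(F)cc2)s1)c1ccc(Br)cc1` gives > 50000 nM
compound 2 `O=C(Nc1ncc(Cc2ccc(Br)cc2)s1)c1ccc2ccccc2c1` gives > 50000 nM
compound 3 `COCCNc1ncc(C(Oc2ccc3cc(Br)ccc3c2)c2ccc(Cl)cc2)s1` gives "not toxic" (no number reported)

In an ADME assay on HepG2 2.2.15 cells (Homo sapiens) for cytotoxicity (a higher number here means that more compound is tolerated, a lower number that less compound is tolerated), compound 1 is reported only as a limit of the assay, > 50000 nM, not as a number. Compound 2 likewise stops at a limit, > 50000 nM. Compound 3 carries no number at all and is simply recorded as "not toxic" (no number reported). Compound 3 therefore stands alongside the other two values, which both sit at the limit of > 50000 nM in this assay, at which 2 of the 3 values shown sit. Compound 4 `Cc1ccc(C(=O)Nc2ncc(C(Oc3ccc4cc(Br)ccc4c3)c3ccc(Cl)cc3)s2)cc1` has not been measured. It differs from compound 3 in one place: (4-methylphenyl)carbonyl in place of 2-methoxyethyl on a nitrogen on an aromatic ring. For the measured compounds named here, no measured pair shows what such a change does in this assay, and all three values sit at the top of what the assay reports, so no direction can be read from them. Compound 4 is expected to come out at 50000 nM, within 20000 nM to 100000 nM, most likely again as a limit only.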

Compound 4, half-maximal cytotoxic concentration: "not toxic" (no number reported)
For compound 4 the study gives words and no number, so the estimate cannot be set against anything.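

Compound 3 and compound 4 are both recorded only in words, as "not toxic", so no step can be read between them. The compounds shown leave open what concentration, if any, harms these cells, as the numbers given stop at: the limit of > 50000 nM in this assay, at which 2 of the 4 values shown sit.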